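Isopropyl for allyl on a sulfonamide nitrogen

The compounds below may be only part of what the source reports. "The series", "measured", "known", "first", "only" and "open" are said of these compounds alone.

Compound 1 `Cc1ccccc1NS(=O)(=O)c1cc(Cl)ccc1Cl` and compound 2 `C=CCN(c1ccccc1C)S(=O)(=O)c1cc(Cl)ccc1Cl` share one core. In an ADME assay on A549 cells (Homo sapiens) for cytotoxicity, read by MTT assay (a higher number here means that more compound is tolerated, a lower number that less compound is tolerated), compound 1 gives a limit of > 5000 nM. In this assay compound 2 likewise gives only a limit of > 5000 nM. The step that the two limits leave unreadable from compound 1 to compound 2 is therefore not readable, since (the limit of > 5000 nM in this assay, at which 2 of the 2 values shown sit). Compound 3 `Cc1ccccc1N(C(C)C)S(=O)(=O)c1cc(Cl)ccc1Cl` differs from compound 2 by isopropyl in place of allyl on a sulfonamide nitrogen. Going by the values given here, no measured step bears readably on this change, so no step beyond the scatter is expected in this assay. For compound 3 the expected value is 10000 nM, with a range from 5000 nM to 30000 nM, most likely again reported as a limit. This estimate means a step that the limit leaves unreadable from compound 2 to compound 3.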

Compound 3, half-maximal cytotoxic concentration: > 5000 nM
Compound 3 gave a limit, no number; the forecaster's own chance of this, stated with the estimate: 85%; the middle value lies beyond the limit too.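

No step can be read among compound 1, compound 2 and compound 3 in this assay, since all three stop at a limit: the limit of > 5000 nM in this assay, at which 3 of the 3 values shown sit.

The compounds shown leave open at what concentration any of them becomes cytotoxic, and whether the three differ at all.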